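Trifluoromethyl on the aryl piperazine of a diphenylhydantoin

A few compounds are considered here, and "the series" means these few. Any claim that something is new, unique, unknown or untested is made for them only; others in the source may bear on it.

Measured compounds:
compound 1, `CC(C)C1(C(C)C)NC(=O)N(CN2CCN(c3cccc(C(F)(F)F)c3)CC2)C1=O`, 100 mg/kg;
compound 2, `O=C1NC(c2ccccc2)(c2ccccc2)C(=O)N1CN1CCN(c2ccccc2)CC1`, 100 mg/kg;
compound 3, `O=C1NC(c2ccccc2)(c2ccccc2)C(=O)N1CN1CCN(c2ccccc2F)CC1`, 30 mg/kg.

In a functional assay on the whole organism (strain CD1) with Mus musculus as the target, in the maximal electroshock model, with a stated time of 4 h (a lower number here means that less compound is needed, a higher number that more compound is needed for the effect), compound 2 gives 100 mg/kg, level with compound 1 and together with it the highest of the three numbers; compound 3 sits lowest. The new compound 4, `O=C1NC(c2ccccc2)(c2ccccc2)C(=O)N1CN1CCN(c2cccc(C(F)(F)F)c2)CC1`, differs from compound 2 by trifluoromethyl in place of hydrogen on an aromatic carbon. Among the measured compounds shown here, only one measured step touches this ring: a 3.3-fold lower number from compound 2 to compound 3 (0.52 log units; beyond the scatter), a modest gain from a different, smaller group. Compound 1 already carries the trifluoromethyl group on another core and gives 100 mg/kg, no better than compound 2. Compound 4 is therefore expected to change little beyond the scatter, a 1.4-fold lower number from compound 2 to compound 4 (0.15 log units; within the scatter), with an estimate of 70 mg/kg and a range from 25 mg/kg to 200 mg/kg.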

Compound 4, minimum effective dose: 100 mg/kg
The estimate for compound 4 lay 1.4-fold (0.15 log units) below the measured number, within the range that was stated.
By their numbers in this assay, from the lowest: compound 3; then compounds 1, 2 and 4 (each within the scatter of the next).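

On the shared core, in this assay, placing trifluoromethyl meta to a large group results in no change at the digits printed from compound 2 to compound 4 (within the scatter), so this change does not bring the gain seen with fluoro. Replacing 2-fluorophenyl with 3-(trifluoromethyl)phenyl gives a 3.3-fold higher number from compound 3 to compound 4 (0.52 log units; beyond the scatter), which leaves compound 3 alone with the lower number among the compounds on this core. Nothing available explains this difference. Compounds 3 and 4 differ in both the group and its place on the ring, and the two effects cannot be separated. On these data alone, how a chlorine or a methoxy group would behave on this ring remains open.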